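Diethylamino for dimethylamino on a longer chain

The compounds below may be only part of what the source reports. "The series", "measured", "known", "first", "only" and "open" are said of these compounds alone.

Measured compounds:
Compound 1 `CN(C)CCCn1c(N)c(-c2nc3cc(Cl)ccc3[nH]2)c2nc(C#N)c(C#N)nc21`: > 50000 nM
Compound 2 `CCN(CC)CCCn1c(N)c(-c2nc3cc(Cl)ccc3[nH]2)c2nc(C#N)c(C#N)nc21`: > 50000 nM
Compound 3 `CN(C)CCCCn1c(-c2c(N)n(C)c3nc(C#N)c(C#N)nc23)nc2ccccc21`: 11200 nM

Of the compounds shown here, three have been tested in a functional assay on A549 cells (Homo sapiens) for antiproliferative activity, read by MTT assay, with a stated time of 48 h; on this read-out lower numbers stand for stronger inhibition and higher numbers for weaker inhibition. For compound 1 the value > 50000 nM is a limit of the assay, not a number. For compound 2 the value > 50000 nM is likewise a limit. Among the measured compounds shown here, compound 3 is the only one with a number, 11200 nM. How the core of compound 3 differs from the core of compound 1 is not broken down here.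

The change from compound 1 to compound 2 is diethylamino in place of dimethylamino on a saturated chain carbon, three bonds along the chain from an aromatic nitrogen. Its size cannot be read: a step that the two limits leave unreadable from compound 1 to compound 2, because both values sit at the limit of > 50000 nM in this assay, at which 2 of the 3 values shown sit.

Compound 4 `CCN(CC)CCCCn1c(-c2c(N)n(C)c3nc(C#N)c(C#N)nc23)nc2ccccc21` is not yet measured. It differs from compound 3 by diethylamino in place of dimethylamino on a saturated chain carbon, four bonds along the chain from an aromatic nitrogen. This is the same kind of change as that from compound 1 to compound 2, but the place differs: three bonds along the chain from an aromatic nitrogen there, four bonds along the chain from an aromatic nitrogen here. Since the earlier step gave no readable size, the expectation for compound 4 rests on compound 3 with its value of 11200 nM as the only anchor. Only a small step is expected, a 1.3-fold higher number from compound 3 to compound 4 (0.13 log units; within the scatter). Compound 4 is therefore expected to give about 15000 nM in this assay, between 5000 nM and 50000 nM.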

Compound 4, half-maximal inhibitory concentration: 13100 nM
Compound 4: middle estimate off by 1.1-fold (0.06 log units), on the high side; the measured number falls inside the stated range.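

In this assay, putting diethylamino in place of dimethylamino on a saturated chain carbon, four bonds along the chain from an aromatic nitrogen, gives a 1.2-fold higher number from compound 3 to compound 4 (0.07 log units; within the scatter), so on this core the two compounds cannot be told apart. The same kind of change on the core of compound 1, three bonds along the chain from an aromatic nitrogen, cannot be read, because compound 1 and compound 2 each give only a limit and not a number: the limit of > 50000 nM in this assay, at which 2 of the 4 values shown sit. The change therefore has one readable size, on one core and at one place on the chain, which means these compounds neither show that it carries from one core to the other nor show that it fails to carry.

The compounds shown leave open whether a ring amine such as pyrrolidine or morpholine in place of diethylamino would give a step beyond the usual scatter on the core of compound 3. They also leave open how a 3-(diethylamino)propyl chain would read on that core, which would separate the effect of chain length from that of the core.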